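The source may report more compounds than this note shows. Statements on the series, on what has been measured and on what is new or still open speak of the compounds shown alone.

Working notes on the series. Compound 1 `CCc1nc(N)nc(N)c1-c1ccc(NCc2ccc(C(C)=O)cc2)cc1` gives 110 nM in a functional assay on CHOK cells for antagonist activity at growth hormone secretagogue receptor type 1 (Homo sapiens), read by calcium flux; a lower number here means a stronger inhibitor, a higher number a weaker inhibitor. Compound 2 `Nc1nc(N)c(-c2ccc(NCc3cc(F)c(S(=O)(=O)C(F)(F)F)c(F)c3)cc2)c(COCc2ccccc2)n1` gives 85 nM in this assay. Compound 3 `CC(=O)c1ccc(CNc2ccc(-c3c(N)nc(N)nc3COCc3ccccc3)cc2)cc1` gives 10 nM in this assay, the lowest of the three numbers: the gap to compound 2 and the gap to compound 1 both lie beyond the scatter. Going by the values given here, the one step counted so far, an 11-fold lower number from compound 1 to compound 3 (1.04 log units; beyond the scatter), changes the side chain on the shared core, not the benzylic substituent.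

The next compound, compound 4 `Nc1nc(N)c(-c2ccc(NCc3csc(Cl)c3)cc2)c(COCc2ccccc2)n1`, keeps the core of compound 3 and differs only in the group on the benzylic carbon: 5-chlorothiophen-3-yl in place of 4-acetylphenyl on a saturated chain carbon bound to a nitrogen on an aromatic ring. Among the compounds with values here, no measured step covers this kind of exchange. Within the data shown here, the only related comparison is compound 2 against compound 3, which differ in the substituents on that same aryl ring and whose numbers stand well apart, showing that the aryl part of the benzylamine is not indifferent. Since the direction of such a change cannot be read from the data, the expected step of a 4.0-fold higher number from compound 3 to compound 4 (0.60 log units; beyond the scatter) is set as a modest loss, with a wide range to either side. The expectation for compound 4 in this assay is therefore 40 nM, between 8 nM and 250 nM.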

Compound 4, half-maximal inhibitory concentration: 170 nM
Estimate against measurement, compound 4: 4.3-fold (0.63 log units) below; low and high end bracket the measured number.
By their numbers in this assay, from the lowest: compound 3; then compounds 2, 1 and 4 (each within the scatter of the next).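

In this assay, going by these compounds alone, the exchange of 4-acetylphenyl for 5-chlorothiophen-3-yl on a saturated chain carbon bound to a nitrogen on an aromatic ring gives a 17-fold higher number from compound 3 to compound 4 (1.23 log units; beyond the scatter), the first direct evidence that this position responds strongly while the rest of the molecule stays fixed. The step is large, as is the earlier side-chain step, an 11-fold lower number from compound 1 to compound 3 (1.04 log units; beyond the scatter), and the benzyloxy side chain alone does not secure a number like that of compound 3: compound 4 carries it and gives 170 nM. The available evidence offers no account of this loss.

The step replaces the ring and removes the acetyl group together, so the share of each remains unresolved; a 4-chlorophenyl group or a thiophene ring bearing an acetyl group would separate the two. From the compounds shown here alone, it also remains open whether 4-acetylphenyl holds its advantage over 5-chlorothiophen-3-yl when the ethyl side chain of compound 1 replaces the benzyloxy side chain.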